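A few compounds are considered here, and "the series" means these few. Any claim that something is new, unique, unknown or untested is made for them only; others in the source may bear on it.

In a functional assay on HeLa cells (Homo sapiens) for antiproliferative activity, read by sulforhodamine B assay, with a stated time of 72 h (a higher number here means a weaker inhibitor, a lower number a stronger inhibitor), three thiosemicarbazones that share one core were examined. Compound 1, `Fc1ccccc1NC(=S)N/N=C/c1ccc2ccccc2n1`, gives only a limit, > 100000 nM. Compound 2, `S=C(N/N=C/c1ccc2ccccc2n1)Nc1ccccc1Br`, likewise reaches only a limit, > 100000 nM. Among the measured compounds shown here, compound 3, `S=C(N/N=C/c1ccc2ccccc2n1)Nc1ccc(Br)cc1`, is the one member of the set with a number, 56800 nM.

Compound 3 differs from compound 2 in that (4-bromophenyl in place of 2-bromophenyl on an amide-type nitrogen), and the step is an at least 1.7-fold lower number from compound 2 to compound 3 (0.24 log units; that floor lies within the scatter). Against compound 1 the step is an at least 1.7-fold lower number from compound 1 to compound 3 (0.24 log units; that floor lies within the scatter). Both floors rest on (the limit of > 100000 nM in this assay, at which 2 of the 3 values shown sit), so neither step can be sized further.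

Compound 2 and compound 1 differ in that (fluoro in place of bromo on an aromatic carbon), and that step is a step that the two limits leave unreadable from compound 2 to compound 1. The untested compound 4, `Fc1ccc(NC(=S)N/N=C/c2ccc3ccccc3n2)cc1`, carries the same kind of change against compound 3: fluoro in place of bromo on an aromatic carbon. The surroundings differ, since in the first pair the place is ortho to a large group and in the second it is para to a large group.

For the measured compounds named here, because the measured instance of this change, a step that the two limits leave unreadable from compound 2 to compound 1, is unreadable, no direction can be taken from it; the one number available is that of compound 3, 56800 nM. Compound 4 is therefore expected to give 80000 nM in this assay, between 30000 nM and 200000 nM. That estimate means a step of a 1.4-fold higher number from compound 3 to compound 4 (0.15 log units; within the scatter), with a real chance that only a limit is reported.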

Compound 4, half-maximal inhibitory concentration: 33200 nM
Compound 4: the middle estimate sits 2.4-fold (0.38 log units) above what was measured; low and high end bracket the measured number.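

In this assay, fluoro in place of bromo on an aromatic carbon, para to a large group, gives a 1.7-fold lower number from compound 3 to compound 4 (0.23 log units; within the scatter), so this one readable instance of the change stays inside the usual scatter and shows no clear effect of the exchange there. Whether that result carries over to the other surroundings in the series cannot be judged, because the matching pair, compound 2 and compound 1, cannot be read, and no second readable instance exists to compare it with: the limit of > 100000 nM in this assay, at which 2 of the 4 values shown sit. Two steps do pass beyond the scatter, an at least 3.0-fold lower number from compound 2 to compound 4 (0.47 log units; beyond the scatter) and an at least 3.0-fold lower number from compound 1 to compound 4 (0.47 log units; beyond the scatter), but each is only a floor and each replaces a 2-substituted phenyl with 4-fluorophenyl, so they speak to the whole aryl group and not to the exchange of fluoro for bromo alone.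

The compounds shown leave open whether a chloro, methoxy or dimethylamino group in place of the fluoro of compound 4 would give a value close to those of compound 3 and compound 4. They also leave open whether an unsubstituted phenyl or a carboxylic acid on that ring would yield a number or only another limit.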